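This account rests on a few compounds, and the source may have more. Where it says the series, first, only, none or still open, it means among the compounds named here.

Compound 1 `O=C1COc2ccc(-c3cnc(Cl)c(NS(=O)(=O)c4ccc(F)cc4)c3)cc2N1c1ccc(F)cc1` gives 32600 nM in a functional assay on MCF7 cells (Homo sapiens) for antiproliferative activity, read by MTT assay, with a stated time of 72 h; a lower number here means a stronger inhibitor, a higher number a weaker inhibitor. Compound 2 `O=C1COc2ccc(-c3cnc(Cl)c(NS(=O)(=O)c4ccc(F)cc4)c3)cc2N1` reaches only the limit of > 40000 nM in this assay. The change from compound 1 to compound 2 is hydrogen in place of 4-fluorophenyl on an amide-type nitrogen in a ring, and it yields an at least 1.2-fold higher number from compound 1 to compound 2 (0.08 log units; that floor lies within the scatter), which is read against (the limit of > 40000 nM in this assay, at which 2 of the 3 values shown sit). Compound 3 `O=C1COc2ccc(-c3cnc4ccccc4c3)cc2N1c1ccc(F)cc1` likewise reaches only the limit of > 40000 nM in this assay. The difference between the core of compound 1 and the core of compound 3 is not broken down here. Compound 4 `O=C1COc2ccc(-c3cnc4ccccc4c3)cc2N1` awaits measurement in this assay. It differs from compound 3 by hydrogen in place of 4-fluorophenyl on an amide-type nitrogen in a ring, the same change as that from compound 1 to compound 2. The step from compound 3 to compound 4 is expected to be a step that the limit leaves unreadable from compound 3 to compound 4, because the earlier one was an at least 1.2-fold higher number from compound 1 to compound 2 (0.08 log units; that floor lies within the scatter). Compound 4 is thus expected at 60000 nM, between 35000 nM and 150000 nM, most likely again a limit.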

Compound 4, half-maximal inhibitory concentration: > 40000 nM
Compound 4 ended at the assay's limit; the forecaster's own chance of this, stated with the estimate: 85%; the middle value lies beyond the limit too.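

Within the data shown here, compound 3 and compound 4 both end at an assay limit, so no step between them can be read: the limit of > 40000 nM in this assay, at which 3 of the 4 values shown sit. Left open is how far either compound lies past that limit, and what 4-fluorophenyl contributes on this core.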